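A few compounds are considered here, and "the series" means these few. Any claim that something is new, unique, unknown or untested is made for them only; others in the source may bear on it.

Compound 1 `CCCCCc1cn(C/C=C(\C)CCC=C(C)C)nn1` and compound 3 `CCCCCc1cn(C/C=C(/C)CCC=C(C)C)nn1` are built from the same atoms and bonds, and how the two cores differ is set out in the two compounds have the same atoms and bonds and differ only in configuration as drawn: 1 of 1 stereo elements differ; a double bond is drawn E in compound 1 and Z in compound 3. In a physicochemical assay for lipophilicity, measured as octanol-water partition (a lower number here means a more polar compound, a higher number a more lipophilic compound), compound 1 gives 5.45, and compound 3 gives 5.45. Between them there is no change at the digits printed from compound 1 to compound 3 (within the scatter), a result that sits with the fact that compounds 1 and 3 differ only in the configuration as drawn. Compound 2 `CC(C)=CCC/C(C)=C/Cn1cc(-c2ccccc2)nn1` carries the change described in phenyl in place of pentyl on an aromatic carbon; in this assay compound 2 gives 4.91. That change made a number 0.54 log units lower from compound 1 to compound 2 (beyond the scatter).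

Compound 4 `CC(C)=CCC/C(C)=C\Cn1cc(-c2ccccc2)nn1` has not yet been measured in this assay. Among the measured compounds shown here, it differs from compound 3 in the way set out in phenyl in place of pentyl on an aromatic carbon, which is the same change as the one made between compound 1 and compound 2, now on the core drawn with the other configuration; among the four compounds this change occurs twice. The expectation for compound 4 rests on two measured steps: the pair of compound 1 and compound 3 shows no change at the digits printed from compound 1 to compound 3 (within the scatter), and the pair of compound 1 and compound 2 shows a number 0.54 log units lower from compound 1 to compound 2 (beyond the scatter), so the same step is expected on the other core. Compound 4 is therefore expected to show a number 0.54 log units lower from compound 3 to compound 4 (beyond the scatter), set beside the earlier step of the same change. Compound 4 is estimated at 4.91, expected to fall between 4.6 and 5.2.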

Compound 4, partition coefficient: 4.91
Compound 4: middle estimate and measured number agree at the digits printed; the range from low to high includes it.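

In this assay, phenyl in place of pentyl on an aromatic carbon gave a number 0.54 log units lower from compound 3 to compound 4 (beyond the scatter), and this matches a number 0.54 log units lower from compound 1 to compound 2 (beyond the scatter), so the change carried from the core of compound 1 to the core of compound 3 with the same size and direction at the digits printed. Among the compounds shown here, the configuration of the double bond left the phenyl pair as it had left the pentyl pair, with no change at the digits printed from compound 2 to compound 4 (within the scatter), and the two compounds of that pair are related as follows: the fact that compounds 2 and 4 differ only in the configuration as drawn This is only two occurrences of one change on two cores with the same atoms and bonds, so it does not show that the step would carry to a core that differs in its atoms or bonds, or that it would hold in any other kind of measurement, and it gives no reason for the size of the step.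

The compounds shown leave open whether the same agreement between the two cores would appear with a different group on that aromatic carbon, such as a longer chain, an amine or a carboxylic acid. They also leave open how the step would read on a core in which the chain on the ring nitrogen is replaced by another group.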